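Rearranging a methylpyridine on a sulfonyl sulfur

The compounds below may be only part of what the source reports. "The series", "measured", "known", "first", "only" and "open" are said of these compounds alone.

Measured so far in a physicochemical assay for lipophilicity, read by HPLC, at pH 7.4 (a higher number here means a more lipophilic compound, a lower number a more polar compound), are two compounds
- compound 1 `CNCc1cn(S(=O)(=O)c2ncccc2C)c(-c2cccnc2F)c1F` with 0.32 as its value
- compound 2 `CNCc1cn(S(=O)(=O)c2cccc(C)n2)c(-c2cccnc2F)c1F` with 0.71 as its value

Compound 2 holds the higher of these two numbers, and the gap to compound 1 lies beyond the scatter. Still unmeasured is compound 3 `CNCc1cn(S(=O)(=O)c2cnccc2C)c(-c2cccnc2F)c1F` which carries 4-methylpyridin-3-yl in place of 6-methylpyridin-2-yl on a sulfonyl sulfur with the same atoms joined differently. For the measured compounds named here, one measured step bears on this change, a modest one that also rearranged this ring, with a number 0.39 log units higher from compound 1 to compound 2 (beyond the scatter) as its result. Compound 3 has a ring not yet tested, so the direction is uncertain. With compound 2 the higher of the pair at 0.71 as the starting point, a modest fall is expected, of similar size to that step. The expected move is a number 0.36 log units lower from compound 2 to compound 3 (beyond the scatter) in this assay as a rough estimate. The estimate for compound 3 is 0.35 with an expected range from 0 to 0.75 overall.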

Compound 3, distribution coefficient: 0.43
Compound 3: the middle estimate sits 0.08 log units below what was measured, within the range that was stated.
By their numbers in this assay, from the lowest: compounds 1, 3 and 2 (each within the scatter of the next, the first and the last beyond it).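

In this assay, placing 4-methylpyridin-3-yl on the sulfonyl sulfur gives a number 0.28 log units lower from compound 2 to compound 3 (within the scatter) and, measured against the other isomer, a number 0.11 log units higher from compound 1 to compound 3 (within the scatter), and both steps stay within the scatter. Compound 3 therefore cannot be told apart from either neighbour, even though compound 1 and compound 2 remain separated by a number 0.39 log units higher from compound 1 to compound 2 (beyond the scatter), so the three ring arrangements with the same atoms do not fall into a clear ranking. Nothing here gives a measured reason for how these arrangements read.

As far as these compounds go, how the number responds to a different kind of group at this position stays open, such as a plain phenyl ring or a pyridine carrying a methoxy group instead of the methyl. Also open, from the compounds shown here alone, is whether a larger change to this group would give a step well beyond the scatter.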